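From Naphthalen-2-yl to Pyridin-3-yl: Tolerance Expected to Hold

This account rests on a few compounds, and the source may have more. Where it says the series, first, only, none or still open, it means among the compounds named here.

Three measured compounds share one core and differ only in the aromatic group attached to the carbonyl carbon. Compound 1 `N#Cc1ccc(C(=O)NC(=S)N2CCc3c(OCCCCCOc4ccc(Cl)cc4)cccc32)cc1` carries a 4-cyanophenyl group there, compound 2 `Cc1ccc(C(=O)NC(=S)N2CCc3c(OCCCCCOc4ccc(Cl)cc4)cccc32)cc1` a 4-methylphenyl group, and compound 3 `O=C(NC(=S)N1CCc2c(OCCCCCOc3ccc(Cl)cc3)cccc21)c1ccc2ccccc2c1` a naphthalen-2-yl group. In an ADME assay on Huh-7 cells (Homo sapiens) for cytotoxicity (a higher number here means that more compound is tolerated, a lower number that less compound is tolerated), compound 1 gives > 50000 nM, which is a limit of the assay rather than a number. In this assay compound 2 likewise gives only the limit > 50000 nM. Compound 3 also reaches only the limit in this assay, namely > 50000 nM. All three therefore stand at the same point, (the limit of > 50000 nM in this assay, at which 3 of the 3 values shown sit), and the steps between them cannot be read: a step that the two limits leave unreadable from compound 1 to compound 2, a step that the two limits leave unreadable from compound 1 to compound 3 and a step that the two limits leave unreadable from compound 2 to compound 3. Compound 4 `O=C(NC(=S)N1CCc2c(OCCCCCOc3ccc(Cl)cc3)cccc21)c1cccnc1` is not yet measured; its change from compound 3 is pyridin-3-yl in place of naphthalen-2-yl on a carbonyl carbon. The two steps that alter the same carbonyl-carbon group, from 4-cyanophenyl and from 4-methylphenyl to naphthalen-2-yl, give no readable size. The expected step from compound 3 to compound 4 is a step that the limit leaves unreadable from compound 3 to compound 4, which in practice means an expectation of staying at the limit. Compound 4 is expected to give about 60000 nM in this assay, within a range from 30000 nM to 120000 nM.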

Compound 4, half-maximal cytotoxic concentration: 11100 nM
Compound 4: the middle estimate sits 5.4-fold (0.73 log units) above what was measured; measured number below the stated range.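

At this carbonyl-carbon position, the aromatic group can change what cells tolerate in this assay, which the three earlier compounds could not show, since the steps among them cannot be read. Pyridin-3-yl gives a lower number than each of the earlier groups (an at least 4.5-fold lower number from compound 3 to compound 4 (0.65 log units; beyond the scatter); an at least 4.5-fold lower number from compound 2 to compound 4 (0.65 log units; beyond the scatter); an at least 4.5-fold lower number from compound 1 to compound 4 (0.65 log units; beyond the scatter)), and among these four compounds it is the only group with a nitrogen in its aromatic ring. Each of these steps gives only a minimum size, because the other end of each step is a limit rather than a number: the limit of > 50000 nM in this assay, at which 3 of the 4 values shown sit.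

Compound 4 differs from compound 3 in both ring count and ring nitrogen, so the compounds shown cannot say whether the nitrogen, the smaller group, or the two together go with the lower number. Plain phenyl would test the ring count without a nitrogen, while pyridin-2-yl and pyridin-4-yl would show whether the place of the nitrogen in the ring matters, and the true tolerated concentrations of compounds 1, 2 and 3 remain unknown.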